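This account rests on a few compounds, and the source may have more. Where it says the series, first, only, none or still open, it means among the compounds named here.

Measured in a functional assay on HCT-116 cells (Homo sapiens) for antiproliferative activity, read by MTT assay, with a stated time of 72 h; on this read-out lower numbers stand for stronger inhibition and higher numbers for weaker inhibition:
- compound 1 `CC(=O)NNC(=O)c1csc2ncc(-c3ccc(C)cc3)n12`: 71800 nM
- compound 2 `CCCC(=O)NNC(=O)c1csc2ncc(-c3ccc(C)cc3)n12`: 34500 nM

Compound 1 stands highest of the two numbers, so it is the weaker of the pair. Compound 3 `COc1ccc(-c2cnc3scc(C(=O)NNC(C)=O)n23)cc1` departs from compound 1 in one place: methoxy in place of methyl on an aromatic carbon. Going by the values given here, the only measured step, a 2.1-fold lower number from compound 1 to compound 2 (0.32 log units; beyond the scatter), is modest and lies elsewhere, with ethyl in place of hydrogen on a saturated chain carbon bound to a carbonyl carbon. Among the compounds with values here, no measured compound carries a change on the aromatic ring, so that step shows only the size one change has reached. In this assay, no shift beyond the scatter is expected, and no direction is favoured. The expected step is a 1.1-fold lower number from compound 1 to compound 3 (0.04 log units; within the scatter). For compound 3 the estimate is 65000 nM, with an expected range of 28000 nM to 130000 nM.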

Compound 3, half-maximal inhibitory concentration: 17000 nM
Estimate against measurement, compound 3: 3.8-fold (0.58 log units) above; the whole stated range lies above it.
By their numbers in this assay, from the lowest: compound 3; then compound 2; then compound 1.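

In this assay, the aromatic carbon para to a large group now counts as a site where a single change moves the number, a point the earlier chain change could not address: methoxy in place of methyl gives a 4.2-fold lower number from compound 1 to compound 3 (0.63 log units; beyond the scatter) on the shared core. By the computed counts, this change adds one carbon-bound oxygen and one hydrogen-bond acceptor, but a single pair cannot separate the contribution of the oxygen from that of the larger group. Nothing measured here bears on the cause of this step.

From the compounds shown here alone, whether methoxy gives a step of similar size when combined with the longer chain of compound 2 remains open. Also open, going by these compounds, is how this ring position responds to other groups, such as ethoxy, hydroxy, an amine or a halogen like chlorine.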